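Swapping a Nitro Group for Acetamido on a Shared Core

This account rests on a few compounds, and the source may have more. Where it says the series, first, only, none or still open, it means among the compounds named here.

Compound 1 `O=[N+]([O-])c1ccc2[nH]c(Cc3ccc(Oc4ccccc4)cc3)nc2c1` was tested in an assay on membranes from brain for binding affinity to Adrenergic receptor alpha-1 (Rattus norvegicus) (a lower number here means a stronger inhibitor, a higher number a weaker inhibitor), and gives 1200 nM. A second compound, compound 2 `Oc1cccc2[nH]c(Cc3ccc(Oc4ccccc4)cc3)nc12`, gives 5500 nM in this assay. Of these two numbers, compound 1 stands lowest, and its gap to compound 2 lies beyond the usual scatter; the two structures differ in more than one place, so the pair says nothing about any single change.

Compound 3 `CC(=O)Nc1ccc2[nH]c(Cc3ccc(Oc4ccccc4)cc3)nc2c1` has not yet been measured. It differs from compound 1 in one place: acetamido in place of nitro on an aromatic carbon. Going by the values given here, no step between measured compounds shows what such a change does in this assay, so the expectation rests on compound 1 alone. A small step toward a higher number, near the edge of the scatter, is expected: a 2.1-fold higher number from compound 1 to compound 3 (0.32 log units; beyond the scatter). Compound 3 is therefore estimated at 2500 nM, with a range from 600 nM to 10000 nM.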

Compound 3, half-maximal inhibitory concentration: 20000 nM
Estimate against measurement, compound 3: 8.0-fold (0.90 log units) below; measured number outside the range, above it.
By their numbers in this assay, from the lowest: compound 1; then compound 2; then compound 3.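

Going by these compounds alone, this is the first change in a single place that can be read in this assay: acetamido in place of nitro on an aromatic carbon gives a 17-fold higher number from compound 1 to compound 3 (1.22 log units; beyond the scatter), a large step beyond the scatter. The number at this position therefore depends strongly on which group sits there, and nitro gives by far the lower number of the two groups compared here on this core. No measurement at hand explains the size of this step, which stands as an observation only.

A single step cannot show whether the rise goes with the amide hydrogen, with the carbonyl, or simply with the loss of nitro. An amine or a nitrile at the same place on the shared core would show whether nitro is unusual or acetamido is.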